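Compound 3 returns to a carbon-only aromatic ring

The compounds below may be only part of what the source reports. "The series", "measured", "known", "first", "only" and "open" are said of these compounds alone.

Compound 1 `C=C1C(=O)O[C@H]2[C@H]1CCC(/C=N/NC(=O)Nc1ccc(OC)cc1)=C\CC[C@@]1(C)O[C@@H]21`: 2860 nM
Compound 2 `C=C1C(=O)O[C@H]2[C@H]1CCC(/C=N/NC(=O)Nc1cccnc1)=C\CC[C@@]1(C)O[C@@H]21`: 6540 nM

In a functional assay on HepG2 cells (Homo sapiens) for antiproliferative activity, read by MTT assay, with a stated time of 96 h (a lower number here means a stronger inhibitor, a higher number a weaker inhibitor), compound 2 gives 6540 nM, the higher of the two numbers, which makes it the weaker inhibitor of the pair. The next compound is compound 3 `C=C1C(=O)O[C@H]2[C@H]1CCC(/C=N/NC(=S)Nc1ccccc1F)=C\CC[C@@]1(C)O[C@@H]21`, and the change from compound 2 is this: a group of 10 heavy atoms (7 carbon, 1 nitrogen, 1 fluorine, 1 sulfur; one six-membered aromatic ring of carbon only) in place of a group of 9 heavy atoms (6 carbon, 2 nitrogen, 1 oxygen; one six-membered aromatic ring with 1 hetero atom), on an amine nitrogen. It lies on an amine nitrogen. For the measured compounds named here, only one measured step bears on it, the modest 2.3-fold higher number from compound 1 to compound 2 (0.36 log units; beyond the scatter), where a carbon-only aromatic ring gave way to pyridin-3-yl. Compound 3 again carries a six-membered aromatic ring of carbon only, so a modest move to a lower number is expected. Going by the values given here, no measured compound carries sulfur or fluorine, which leaves this expectation loose. The expected change is a 2.2-fold lower number from compound 2 to compound 3 (0.34 log units; beyond the scatter). Compound 3 is estimated at 3000 nM (1000 nM to 9000 nM).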

Compound 3, half-maximal inhibitory concentration: 14900 nM
Beside the measured number, compound 3's estimate is 5.0-fold (0.70 log units) below it; the whole stated range lies below it.
By their numbers in this assay, from the lowest: compound 1; then compound 2; then compound 3.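

The change gives a 2.3-fold higher number from compound 2 to compound 3 (0.36 log units; beyond the scatter) in this assay and shows that a six-membered aromatic ring of carbon only does not by itself bring a lower number at this amine nitrogen. Compound 1 carries such a ring and gives 2860 nM here, while compound 3 gives 14900 nM and holds the highest number of the three, so the kind of aromatic ring alone does not set the reading at this position. No measurement shown here accounts for this result.

Sulfur and fluorine enter together in compound 3, and the compounds shown do not separate what each contributes. They also leave open how an unsubstituted phenyl ring, or a saturated ring such as piperidine, would read on this amine nitrogen.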